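A few compounds are considered here, and "the series" means these few. Any claim that something is new, unique, unknown or untested is made for them only; others in the source may bear on it.

Compound 3 `Cc1cccc2sc(NC(=O)CCN3CCN(CC4CCCCC4)CC3)nc12` stands lowest of the two numbers given in an assay on membranes from liver for displacement of a labelled ligand from Sigma intracellular receptor 2 (Rattus norvegicus), read by scintillation counting, with a stated time of 120 min (a higher number here means a weaker inhibitor, a lower number a stronger inhibitor), where compound 3 gives 519 nM. Its nearest neighbour is compound 1 `CCN1CCN(CCC(=O)Nc2nc3c(C)cccc3s2)CC1`, which in this assay gives 1200 nM. Compound 2 `Cc1cccc2sc(NC(=O)CCN3CCN(CCN(C)C)CC3)nc12` reaches only a limit of this assay, giving > 1000 nM (the limit of > 1000 nM in this assay, at which 1 of the 3 values shown sits). The change to compound 4 `Cc1cccc2sc(NC(=O)CCN3CCN(CCN(C(C)C)C(C)C)CC3)nc12` is (diisopropylamino)methyl in place of cyclohexyl on a saturated chain carbon bound to an amine nitrogen in a ring. Of the measured steps, a 2.3-fold lower number from compound 1 to compound 3 (0.36 log units; beyond the scatter) bears on it, as does an at least 1.9-fold lower number from compound 2 to compound 3 (0.28 log units; that floor lies within the scatter), while a step that the limit leaves unreadable from compound 1 to compound 2 cannot be read. Since an at least 1.9-fold lower number from compound 2 to compound 3 (0.28 log units; that floor lies within the scatter) ran towards the cyclohexyl and the amine-bearing chain sat at the limit, compound 4 is expected to move upward from compound 3, a 2.3-fold higher number from compound 3 to compound 4 (0.36 log units; beyond the scatter). Compound 4 is therefore estimated to give 1200 nM in this assay, with a likely range from 400 nM to 3500 nM, and a real chance that this assay returns only a limit for compound 4.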

Compound 4, inhibition constant: 121 nM
The estimate for compound 4 lay 9.9-fold (1.00 log units) above the measured number; measured number below the stated range.
By their numbers in this assay, from the lowest: compound 4; then compound 3; then compound 1.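

In this assay, an amine on the chain at this position does not by itself go with a higher number: the 2-(diisopropylamino)ethyl group gives the lowest number of those shown (a 4.3-fold lower number from compound 3 to compound 4 (0.63 log units; beyond the scatter)) and (a 9.9-fold lower number from compound 1 to compound 4 (1.00 log units; beyond the scatter)). Going by these compounds alone, what the earlier compounds could not show is that the groups on that amine nitrogen decide the outcome, with diisopropylamino and dimethylamino far apart (an at least 8.2-fold lower number from compound 2 to compound 4 (0.91 log units; beyond the scatter)). Compound 2 gives only a limit of the assay, so this step is a floor: the limit of > 1000 nM in this assay, at which 1 of the 4 values shown sits.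

The compounds shown leave open whether a diethylamino or a piperidine at the chain end would behave like diisopropylamino or like dimethylamino, and whether a longer chain would keep the lower number. Two amines alone give no trend across such groups.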